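The source may report more compounds than this note shows. Statements on the series, on what has been measured and on what is new or still open speak of the compounds shown alone.

Working notes on the series, all read in a functional assay on SW480 cells (Homo sapiens) for antiproliferative activity, read by MTT assay, with a stated time of 48 h; on this read-out higher numbers stand for weaker inhibition and lower numbers for stronger inhibition. Compound 1 (`CCCCCC(CCO)n1cnc2c(Cl)ncnc21`) gives > 50000 nM, which is a limit of the assay and not a number. Compound 2 (`CCCCCCC(CCO)n1cnc2c(Cl)ncnc21`) gives 16700 nM. Among the measured compounds shown here, compound 3 (`C=C(CO)C(CCCCCC)n1cnc2c(Cl)ncnc21`) gives 32000 nM, level with the only other exact number: a 1.9-fold higher number from compound 2 to compound 3 (0.28 log units; within the scatter).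

Compound 4 (`C=C(CO)C(CCCCCCCC)n1cnc2c(Cl)ncnc21`) departs from compound 3 in one place: ethyl in place of hydrogen on a saturated chain carbon, seven bonds along the chain from an aromatic nitrogen and a double-bonded chain carbon. This puts ethyl in place of hydrogen on a saturated chain carbon, seven bonds along the chain from an aromatic nitrogen and a double-bonded chain carbon, and leaves the 1-(hydroxymethyl)ethenyl group untouched.

For the measured compounds named here, the nearest precedent is a single step of the same kind, methyl in place of hydrogen on a saturated chain carbon: an at least 2.9-fold lower number from compound 1 to compound 2 (0.47 log units; beyond the scatter). That step was made on the 2-hydroxyethyl compounds and starts from a limit, so it gives direction and a bound rather than an exact size. The step between the two exact numbers concerns the other group and says little about the chain. A modest move to a lower number is therefore expected in this assay, probably beyond the scatter, though one precedent leaves this uncertain. The expected step is a 3.2-fold lower number from compound 3 to compound 4 (0.51 log units; beyond the scatter). For compound 4 the estimated value is 10000 nM, with an expected range of 3500 nM to 28000 nM.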

Compound 4, half-maximal inhibitory concentration: 16200 nM
Beside the measured number, compound 4's estimate is 1.6-fold (0.21 log units) below it; the range from low to high includes it.
By their numbers in this assay, from the lowest: compounds 4, 2 and 3 (each within the scatter of the next). At a limit, above all of these: compound 1.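

In this assay, the step on the 1-(hydroxymethyl)ethenyl compounds is a 2.0-fold lower number from compound 3 to compound 4 (0.30 log units; within the scatter). Among the compounds shown here, it is the first chain step with an exact number at both ends, and it shows that ethyl in place of hydrogen at this saturated chain carbon does not separate the two compounds. For the compounds shown here, the only earlier chain step, an at least 2.9-fold lower number from compound 1 to compound 2 (0.47 log units; beyond the scatter), has the same direction and lies beyond the scatter, but it puts methyl rather than ethyl on the chain and was read on the 2-hydroxyethyl compounds, so the pair gives no single size for chain extension. The size of that earlier step remains a bound because compound 1 sits at a limit and not at a number: the limit of > 50000 nM in this assay, at which 1 of the 4 values shown sits.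

From the compounds shown here alone, whether a longer chain on the 1-(hydroxymethyl)ethenyl compounds would give a step beyond the scatter remains open, as one step cannot define a trend. Also open, going by these compounds, is whether a chain carrying an amine or a carboxylic acid at this place would give a different reading in this assay.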